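Weakly active quinolone-type topoisomerase inhibitors and an amine swap

A few compounds are considered here, and "the series" means these few. Any claim that something is new, unique, unknown or untested is made for them only; others in the source may bear on it.

Compound 3 `O=C(O)c1cn(Cc2ccc(-c3ccccc3)cc2)c2cc(N3CC4CNCC4C3)c(F)cc2c1=O` gives 33300 nM in an assay on isolated protein for inhibition of DNA topoisomerase 1 (Homo sapiens), with a stated time of 15 min; on this read-out lower numbers stand for stronger inhibition and higher numbers for weaker inhibition. Among the three measured compounds it stands lowest: compound 1 `CNC(=O)c1cn(Cc2ccc(-c3ccccc3)cc2)c2c(OC)c(N3CC[C@@H](CN)C3)c(F)cc2c1=O` gives 82100 nM in this assay, and compound 2 `O=C(O)c1cn(Cc2ccc(-n3cccn3)cc2)c2cc(N3CC4CNCC4C3)c(F)cc2c1=O` gives 173000 nM. Within the data shown here, the only single-point step recorded is a 5.2-fold lower number from compound 2 to compound 3 (0.72 log units; beyond the scatter), which concerns the distal aryl end of the molecule. Compound 1 differs from compound 3 in several places at once, so its gap to compound 3 cannot be assigned to one change.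

Compound 4 `O=C(O)c1cn(Cc2ccc(-c3ccccc3)cc2)c2cc(NC[C@@H]3CCNC3)c(F)cc2c1=O` has not been measured. It differs from compound 3 as follows: a group of 7 heavy atoms (5 carbon, 2 nitrogen; one five-membered non-aromatic ring with 1 hetero atom) in place of a group of 8 heavy atoms (6 carbon, 2 nitrogen; 2 five-membered non-aromatic rings with 1 hetero atom each), on an aromatic carbon. Among the measured compounds shown here, no measured step bears on this change; the one recorded step touches a different part of the structure, and no pair of measured compounds differs only in the amine attached ortho to the fluoro group. Any expectation therefore rests on the weak overall level of the series and on the general scale of the steps already seen.

He expects compound 4 to remain in the same weak range, and the step of a 1.4-fold higher number from compound 3 to compound 4 (0.13 log units; within the scatter) is estimated to be small, possibly within the scatter, with a slight lean toward a higher number. He estimates compound 4 at 45000 nM, with a range from 15000 nM to 150000 nM.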

Compound 4, half-maximal inhibitory concentration: 104000 nM
Beside the measured number, compound 4's estimate is 2.3-fold (0.36 log units) below it; measured number inside the range.
By their numbers in this assay, from the lowest: compound 3; then compounds 1, 4 and 2 (each within the scatter of the next, the first and the last beyond it).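

Among these compounds, at this position, on an aromatic carbon ortho to a fluoro group, the first step with only the amine changed gives, in this assay, a 3.1-fold higher number from compound 3 to compound 4 (0.49 log units; beyond the scatter), so replacing the group with two five-membered non-aromatic rings by ((pyrrolidin-3-yl)methyl)amino moves the number beyond the scatter and in the weaker direction. This shows that the amine here has a measurable effect on the read-out, and that the step is also rated modest, like the change at the distal aryl end, a 5.2-fold lower number from compound 2 to compound 3 (0.72 log units; beyond the scatter), so both ends of the molecule can shift the number in this weakly active series. Nothing among the available data gives a reason for the step at the amine.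

The single step alters the ring count and the way the amine is attached at once, so the compounds shown do not separate these two features, and they leave open how the mirror-image ((pyrrolidin-3-yl)methyl)amino group would compare. They also leave open whether a piperazine or an open-chain amine such as 2-aminoethylamino at this carbon would give a stronger or a weaker number than the two amines seen here.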